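The source may hold more compounds than are shown below. What is called first, only, known or untested is meant among the compounds shown, and "the series" means these compounds.

Compounds measured so far:

- compound 1, `Cc1cc(-c2ccc(Cl)cc2Cl)c(S(C)(=O)=O)cc1C(=O)N=C(N)N`; in a functional assay for inhibition of sodium/hydrogen exchanger (Oryctolagus cuniculus) (a higher number here means a weaker inhibitor, a lower number a stronger inhibitor), compound 1 gives 42 nM
- compound 2, `CSc1cc(C)c(C(=O)N=C(N)N)cc1S(C)(=O)=O`; compound 2 gives 6 nM
- compound 3, `CCOc1cc(C)c(C(=O)N=C(N)N)cc1S(C)(=O)=O`; compound 3 gives 19 nM

Compound 3 stands second highest of the three numbers: a 2.2-fold lower number from compound 1 to compound 3 (0.34 log units; beyond the scatter), and a 3.2-fold higher number from compound 2 to compound 3 (0.50 log units; beyond the scatter). The three compounds differ only at one aromatic carbon of the shared core, where compound 1 carries a 2,4-dichlorophenyl, compound 2 a methylsulfanyl and compound 3 an ethoxy.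

Compound 4, `Cc1cc(OC2CCCCC2)c(S(C)(=O)=O)cc1C(=O)N=C(N)N`, is not yet measured. It differs from compound 3 as follows: cyclohexyl in place of ethyl on an oxygen on an aromatic ring.

For the measured compounds named here, no measured step changes the group on the oxygen itself, so the bearing of the existing steps is indirect. The comparisons at that aromatic carbon are a 7.0-fold lower number from compound 1 to compound 2 (0.85 log units; beyond the scatter) and a 2.2-fold lower number from compound 1 to compound 3 (0.34 log units; beyond the scatter); the largest group there, in compound 1, gave the highest number of the three. Cyclohexyl enters in place of ethyl, a larger group, so a modest rise in the number is expected rather than none: a 1.8-fold higher number from compound 3 to compound 4 (0.27 log units; within the scatter) is the expected step. Compound 4 is therefore estimated at 35 nM, with an expected range of 10 nM to 120 nM.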

Compound 4, half-maximal inhibitory concentration: 37 nM
The estimate for compound 4 lay 1.1-fold (0.02 log units) below the measured number; low and high end bracket the measured number.
By their numbers in this assay, from the lowest: compound 2; then compounds 3, 4 and 1 (each within the scatter of the next, the first and the last beyond it).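

In this assay, the change on the oxygen itself, cyclohexyl in place of ethyl, gives a 1.9-fold higher number from compound 3 to compound 4 (0.29 log units; within the scatter), so the two ethers cannot be told apart despite the added ring and the larger carbon count. Cyclohexyloxy in place of methylsulfanyl gives a 6.2-fold higher number from compound 2 to compound 4 (0.79 log units; beyond the scatter), a clear separation, while cyclohexyloxy in place of 2,4-dichlorophenyl gives a 1.1-fold lower number from compound 1 to compound 4 (0.06 log units; within the scatter), so compound 4 cannot be told apart from compound 1 and methylsulfanyl in compound 2 remains alone at the low end of the four numbers. Nothing available on these compounds accounts for any of these differences.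

Open, as far as these compounds go, is how an amine or a methoxy on this aromatic carbon would compare with methylsulfanyl. Also open, from the compounds shown here alone, is whether a longer chain such as butyl, or a phenyl, on the oxygen would stay within the scatter of ethyl.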